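Aryl ether variation on the shared phosphoserine core

The source may report more compounds than this note shows. Statements on the series, on what has been measured and on what is new or still open speak of the compounds shown alone.

Compound 3 `N[C@@H](COP(=O)(O)OCCCOC(=O)CCc1ccccc1OCc1cccc(Oc2ccc(F)cc2)c1)C(=O)O` gives 18.7% in an assay on cells for agonist activity at probable G-protein coupled receptor 34 (Mus musculus), with a stated time of 1 h (on this read-out higher numbers stand for larger maximal responses and lower numbers for smaller maximal responses), the second highest of three numbers; compound 2 `Cc1ccc(Oc2cccc(COc3ccccc3CCC(=O)OCCCOP(=O)(O)OC[C@H](N)C(=O)O)c2)cc1` gives 18.2% and compound 1 `Cc1ccccc1Oc1cccc(COc2ccccc2CCC(=O)OCCCOP(=O)(O)OC[C@H](N)C(=O)O)c1` gives 20.3%, both within the scatter of compound 3. Compound 4 `CC(C)(C)c1cccc(Oc2cccc(COc3ccccc3CCC(=O)OCCCOP(=O)(O)OC[C@H](N)C(=O)O)c2)c1` carries 3-(tert-butyl)phenyl in place of 4-fluorophenyl on an oxygen on an aromatic ring. Every measured step in this series exchanges the aryl group on that same oxygen: a number 2.1 percentage points lower from compound 1 to compound 2 (within the scatter), a number 1.6 percentage points lower from compound 1 to compound 3 (within the scatter) and a number 0.5 percentage points higher from compound 2 to compound 3 (within the scatter), none of them beyond the scatter. Within the data shown here, no measured step brings in the 3-(tert-butyl)phenyl group, so the expectation for compound 4 rests only on the flat response to the aryl swaps seen so far. Compound 4 is therefore expected to give 19%, between 10% and 30%, an estimated step of a number 0.3 percentage points higher from compound 3 to compound 4 (within the scatter) not beyond the scatter.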

Compound 4, largest response reached (Emax), in percent of the reference or control that the assay uses: 19.9%
Beside the measured number, compound 4's estimate is 0.9 percentage points below it; the measured number falls inside the stated range.
By their numbers in this assay, from the lowest: compounds 2, 3, 4 and 1 (each within the scatter of the next).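

Replacing the aryl group on this oxygen with 3-(tert-butyl)phenyl leaves this assay flat: a number 1.2 percentage points higher from compound 3 to compound 4 (within the scatter), a number 1.7 percentage points higher from compound 2 to compound 4 (within the scatter) and a number 0.4 percentage points lower from compound 1 to compound 4 (within the scatter). The earlier compounds shown here carried only a methyl or a fluoro on this aryl ring, so the flat response now extends to a tert-butyl group as well. Nothing at hand accounts for this flatness.

Open, as far as these compounds go, is whether an amine or a carboxylic acid on this aryl ring would give a step beyond the scatter. Also open, from the compounds shown here alone, is whether changes to the shared core, rather than to this aryl group, would shift the maximal response.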